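Pentan-3-yl to phenyl to benzyl at the chain carbon

The source may report more compounds than this note shows. Statements on the series, on what has been measured and on what is new or still open speak of the compounds shown alone.

Compound 1, `CCC(CC)C(/C=C1\OC(=O)NC1=O)c1ccc(-c2ccc3cccc(F)c3c2)[nH]c1=O`, gives in an assay on membranes from Chem-1 cells for displacement of a labelled ligand from prostaglandin E2 receptor EP3 subtype (Homo sapiens), read by scintillation counting, with a stated time of 2 h (a higher number here means a weaker inhibitor, a lower number a stronger inhibitor), a value of 13 nM. Compound 2, `O=C1NC(=O)/C(=C/C(c2ccccc2)c2ccc(-c3ccc4cccc(F)c4c3)[nH]c2=O)O1`, gives in this assay a value of 23 nM. The one step between them is a 1.8-fold higher number from compound 1 to compound 2 (0.25 log units; within the scatter), so on the numbers shown compound 2 stands alongside compound 1, separated only by a gap that the scatter covers; with two compounds measured there is no further reference point.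

Compound 3, `O=C1NC(=O)/C(=C/C(Cc2ccccc2)c2ccc(-c3ccc4cccc(F)c4c3)[nH]c2=O)O1`, differs from compound 2 by benzyl in place of phenyl on a saturated chain carbon bound to an aromatic carbon and a double-bonded chain carbon. Going by the values given here, the only measured step that bears on this place is a 1.8-fold higher number from compound 1 to compound 2 (0.25 log units; within the scatter), where exchanging one group for another on the same saturated chain carbon moved the number by an amount within the scatter. Nothing measured here distinguishes a one-carbon-longer link to the ring from the groups already tried. The expected step is therefore a 1.1-fold higher number from compound 2 to compound 3 (0.04 log units; within the scatter), no more than the scatter. Compound 3 is expected to give about 25 nM in this assay, with a range from 9 nM to 70 nM.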

Compound 3, inhibition constant in the prostaglandin E2 receptor EP3 subtype assay: 33 nM
Estimate against measurement, compound 3: 1.3-fold (0.12 log units) below, and the stated range covers the measured number.
By their numbers in the prostaglandin E2 receptor EP3 subtype assay, from the lowest: compounds 1, 2 and 3 (each within the scatter of the next, the first and the last beyond it).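

In the prostaglandin E2 receptor EP3 subtype assay, benzyl in place of phenyl at this saturated chain carbon gives a 1.4-fold higher number from compound 2 to compound 3 (0.16 log units; within the scatter), so on binding alone compound 3 cannot be told apart from compound 2. Benzyl in place of pentan-3-yl gives a 2.5-fold higher number from compound 1 to compound 3 (0.40 log units; beyond the scatter), the first gap at this place to clear the scatter, and only a modest one, so this position has so far tolerated all three groups with little loss. In a physicochemical assay for solubility, in phosphate buffer, measured as kinetic solubility (a lower number here means a less soluble compound, a higher number a more soluble compound), compound 2 gives 32800 nM and compound 3 gives 9100 nM. The clearer cost of the benzyl group appears in the physicochemical assay, where the same exchange that leaves binding within the scatter lowers solubility: the measured solubility of compound 2, 32800 nM, and of compound 3, 9100 nM, a 3.6-fold lower number (0.56 log units; beyond the scatter)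

Still open, on these data alone, is whether a group carrying an amine or a carboxylic acid at this saturated chain carbon would keep the number in the prostaglandin E2 receptor EP3 subtype assay close to those of compounds 1 and 2 while giving a higher solubility than compound 3. Also open, as far as these compounds go, is whether a longer chain ending in phenyl, such as phenethyl, would extend the drift seen from compound 2 to compound 3 beyond the scatter or leave it flat.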